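This account rests on a few compounds, and the source may have more. Where it says the series, first, only, none or still open, it means among the compounds named here.

Measured so far:
compound 1 `Cc1nn(-c2ncnc3nc[nH]c23)c2c1C(OCCc1ccccc1)CC(=O)N2` – 3 nM
compound 2 `CCC(C(=O)NC1CC(=O)Nc2c1c(C)nn2-c1ncnc2nc[nH]c12)c1ccccc1` – 5 nM
compound 3 `O=C1/C(=C/NCCCO)C(c2ccccc2)=NN1c1nc2ccccc2s1` – 200 nM

All three numbers come from a functional assay on HEK293 cells for agonist activity at G-protein coupled receptor 39 (Homo sapiens), read by scintillation proximity assay and inositol phosphate accumulation, with a stated time of 75 min, in the presence of a further agent that is not named here; a lower number here means that less compound is needed, a higher number that more compound is needed for the effect. Compound 1 has the lowest number of the three. Compound 2 lies nearest, within the scatter of compound 1, so no order between these two can be read. Compound 3 lies far beyond the scatter and needs much more compound than either of the others; it also rests on a different core, so its gap says little about the change considered here.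

Compound 4 `Cc1nn(-c2ncnc3nc[nH]c23)c2c1C(C(=O)N(C)c1ccccc1)CC(=O)N2` is not yet measured. It differs from compound 1 in one place: methyl(phenyl)carbamoyl in place of phenethyloxy on a saturated ring carbon. Among the measured compounds shown here, no measured pair shows this exact step, so its size in this assay must be estimated. Compound 1 and compound 2 together show that two members of the shared core sit close to each other at low numbers, and compound 2 with 5 nM gives some ground to expect that compound 4 stays in the same region. A small step toward a higher number is expected, at most modestly beyond the scatter: a 2.7-fold higher number from compound 1 to compound 4 (0.43 log units; beyond the scatter). Compound 4 is estimated at 8 nM, with a range of 2 nM to 40 nM.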

Compound 4, half-maximal effective concentration: 32 nM
Compound 4: middle estimate off by 4.0-fold (0.60 log units), on the low side; measured number inside the range.
By their numbers in this assay, from the lowest: compounds 1 and 2 (each within the scatter of the next); then compound 4; then compound 3.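

In this assay the saturated ring carbon of the shared core proves sensitive to the group it carries: methyl(phenyl)carbamoyl in place of phenethyloxy gives an 11-fold higher number from compound 1 to compound 4 (1.03 log units; beyond the scatter) and thus a large change at this one position. The two groups match in their counts of aromatic rings, hydrogen-bond donors and hydrogen-bond acceptors and differ little in heavy atoms, so these counts do not account for the size of the step. No measurement of any property of the two compounds bears on this result, and the step stands without an explanation.

Still open, going by these compounds, is which part of the change carries the step: the carbonyl, the methyl on the amide nitrogen, or the different link between the ring carbon and the phenyl ring, which a secondary amide with the amide hydrogen in place of that methyl or an ether with a shorter or longer chain would help to separate. Also open, on these data alone, is how this ring carbon responds to a group without a phenyl ring, such as an amine or a carboxylic acid.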